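The compounds below may be only part of what the source reports. "The series", "measured", "known", "first", "only" and "open" are said of these compounds alone.

Measured compounds:
Compound 1 `O=[N+]([O-])c1ccc(C2=NOC(c3ccc(N4CCN(Cc5ccc(F)nc5)CC4)cc3)C2)o1`: in an ADME assay on WI-38 cells (Homo sapiens) for cytotoxicity, read by MTT assay, with a stated time of 96 h (a higher number here means a weaker inhibitor, a lower number a stronger inhibitor), compound 1 gives > 50000 nM, which is a limit of the assay and not a number.
Compound 2 `O=[N+]([O-])c1ccc(C2=NOC(c3ccc(-c4ccccn4)cc3)C2)o1`: in this assay compound 2 gives > 50000 nM, again a limit and not a number.

Compound 1 thus stands at the limit of this assay rather than at a measured number, and every value shown sits there as well (the limit of > 50000 nM in this assay, at which 2 of the 2 values shown sit). Compound 3 `O=[N+]([O-])c1ccc(C2=NOC(c3ccc(N4CCN(Cc5ccncc5)CC4)cc3)C2)o1` is not yet measured. It differs from compound 1 in one place: pyridin-4-yl in place of 6-fluoropyridin-3-yl on a saturated chain carbon bound to an amine nitrogen in a ring. For the measured compounds named here, no step between two measured compounds is given, so the effect of this change cannot be read from measured pairs. The expectation is a step of no size beyond the scatter, in neither direction, so that compound 3 also stays at the limit. For compound 3 the estimate in this assay is 60000 nM, with a range from 30000 nM to 150000 nM. The expected step is a step that the limit leaves unreadable from compound 1 to compound 3.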

Compound 3, half-maximal inhibitory concentration: > 50000 nM
Compound 3 was reported as a limit (the forecaster's own chance of this, stated with the estimate: 85%); the middle value is on the limit's open side.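

For the compounds shown here, compound 3, like compound 1, stops at a limit in this assay and not at a number, so no step between the two can be read: the limit of > 50000 nM in this assay, at which 3 of the 3 values shown sit. The compounds shown leave open whether pyridin-4-yl in place of 6-fluoropyridin-3-yl changes cytotoxicity at all.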